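A few compounds are considered here, and "the series" means these few. Any claim that something is new, unique, unknown or untested is made for them only; others in the source may bear on it.

Measured compounds:
compound 1, `COc1cc(C2CC(c3ccc([N+](=O)[O-])cc3)=NN2C(C)=O)ccc1OCc1cn(Cc2ccc([N+](=O)[O-])cc2)nn1`, 72% in a functional assay on A549 cells (Homo sapiens) for inhibition, read by sulforhodamine B assay, tested at 100 uM; a higher number here means more inhibition of growth at the concentration tested, a lower number less inhibition of growth
compound 2, `COc1cc(C2CC(c3ccc(Br)cc3)=NN2C(C)=O)ccc1OCc1cn(Cc2ccc([N+](=O)[O-])cc2)nn1`, 17%
compound 3, `COc1cc(C2CC(c3ccccc3)=NN2C(C)=O)ccc1OCc1cn(Cc2ccc([N+](=O)[O-])cc2)nn1`, 11%

Compound 3 stands at the bottom of these three numbers in this assay. Its nearest neighbour is compound 2, which lies within the scatter of it, as the step of a number 6 percentage points lower from compound 2 to compound 3 (within the scatter) shows; compound 1 is far above it, the step of a number 61 percentage points lower from compound 1 to compound 3 (beyond the scatter) being large and beyond the scatter.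

Compound 4, `COc1cc(C2CC(c3cc(OC)c(OC)c(OC)c3)=NN2C(C)=O)ccc1OCc1cn(Cc2ccc([N+](=O)[O-])cc2)nn1`, is not yet measured. It differs from compound 3 in one place: 3,4,5-trimethoxyphenyl in place of phenyl on a carbon with a double bond to nitrogen.

For the measured compounds named here, no measured step exchanges phenyl for a trimethoxyphenyl, so none bears directly on this change. The steps that touch the same aryl ring show that what sits on it can matter greatly: a number 55 percentage points lower from compound 1 to compound 2 (beyond the scatter) and a number 61 percentage points lower from compound 1 to compound 3 (beyond the scatter) are large, whereas a number 6 percentage points lower from compound 2 to compound 3 (within the scatter) is within the scatter. A step of some size in either direction is therefore possible, and the direction cannot be read from these three compounds.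

Compound 4 is expected to give about 25% in this assay, with a range from 5% to 60%, which means an expected step of a number 14 percentage points higher from compound 3 to compound 4 (beyond the scatter) from compound 3 to compound 4.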

Compound 4, percent growth inhibition at one concentration: 85%
For compound 4 the middle estimate is 60 percentage points below the measured one; the measured number lies above the stated range.
By their numbers in this assay, from the lowest: compounds 3 and 2 (each within the scatter of the next); then compound 1; then compound 4.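

In this assay, the 3,4,5-trimethoxyphenyl group shows that this position on the carbon with a double bond to nitrogen can carry something other than 4-nitrophenyl and still give high growth inhibition, with a number 74 percentage points higher from compound 3 to compound 4 (beyond the scatter) and, in place of 4-bromophenyl, a number 68 percentage points higher from compound 2 to compound 4 (beyond the scatter). It also exceeds the 4-nitrophenyl group, with a number 13 percentage points higher from compound 1 to compound 4 (beyond the scatter), a modest step but one beyond the scatter, so among these four compounds the highest number no longer belongs to the nitro compound. Nothing measured here accounts for these gains at this position.

The compounds shown leave open whether all three methoxy groups are needed, or whether a single methoxy group, a hydroxyl group or an amine on the same aryl ring would give a similar number. They also leave open whether the order seen at this single concentration in this assay would hold across a range of concentrations or in other cell lines.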